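From 2-aminophenyl to 3-aminophenyl on the amide nitrogen

The compounds below may be only part of what the source reports. "The series", "measured", "known", "first", "only" and "open" are said of these compounds alone.

Among the measured compounds shown here, in a functional assay on KB cells (Homo sapiens) for antiproliferative activity, read by sulforhodamine B assay, with a stated time of 48 h (a higher number here means a weaker inhibitor of growth, a lower number a stronger inhibitor of growth), compound 1 `COc1ccc(S(=O)(=O)Nc2ccccc2CCc2ccc(C(=O)Nc3ccccc3N)cc2)cc1` gives 23 nM as the lowest of the three numbers measured so far. Compound 2 `Nc1ccccc1NC(=O)c1ccc(CCc2ccccc2NS(=O)(=O)c2ccc(F)cc2)cc1` stands at 884 nM in the same measurement. Compound 3 `COc1ccc(S(=O)(=O)Nc2ccccc2CCc2ccc(C(=O)Nc3ccccc3N)cc2)cc1OC` stands at 888 nM in the same measurement. These two higher numbers do not separate, with a 1.0-fold higher number from compound 2 to compound 3 (0.00 log units; within the scatter) between them. Both steps away from compound 1 were large: a 38-fold higher number from compound 1 to compound 2 (1.58 log units; beyond the scatter) with fluoro in place of methoxy on an aromatic carbon, and a 39-fold higher number from compound 1 to compound 3 (1.59 log units; beyond the scatter) with methoxy in place of hydrogen on an aromatic carbon.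

The change to compound 4 `COc1ccc(S(=O)(=O)Nc2ccccc2CCc2ccc(C(=O)Nc3cccc(N)c3)cc2)cc1` is 3-aminophenyl in place of 2-aminophenyl on an amide-type nitrogen and it puts 3-aminophenyl in place of 2-aminophenyl on an amide-type nitrogen. The two compounds have the same atoms, joined differently. For the measured compounds named here, no measured step alters the group at this place, so the data bear on it only indirectly. Going by the values given here, a higher number is still expected, with a 38-fold higher number from compound 1 to compound 2 (1.58 log units; beyond the scatter) and a 39-fold higher number from compound 1 to compound 3 (1.59 log units; beyond the scatter) as the only guides to direction and size, and the uncertainty stays wide. The estimated step is an 87-fold higher number from compound 1 to compound 4 (1.94 log units; beyond the scatter) in this assay for now. Compound 4 is estimated at 2000 nM with an expected range from 200 nM to 20000 nM as the working figure.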

Compound 4, concentration for 50% growth inhibition: 697 nM
For compound 4 the middle estimate is 2.9-fold (0.46 log units) above the measured one; the measured number falls inside the stated range.
By their numbers in this assay, from the lowest: compound 1; then compounds 4, 2 and 3 (each within the scatter of the next).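

In this assay, the change to 3-aminophenyl in place of 2-aminophenyl on the amide-type nitrogen gives a 30-fold higher number from compound 1 to compound 4 (1.48 log units; beyond the scatter), so the series now has a large step at this place as well as the large steps already seen in the group on the sulfonyl sulfur. The two groups have the same heavy-atom, hydrogen-bond donor and acceptor counts and no net charge, so those counts do not separate them, and the step goes with how the same atoms are joined. Nothing available explains the step.

With only these two groups at this place, the compounds shown leave open how 4-aminophenyl, 2-hydroxyphenyl or unsubstituted phenyl on the amide-type nitrogen would read in this assay. They also leave open whether the same change gives a step of similar size when 4-fluorophenyl or 3,4-dimethoxyphenyl stands on the sulfonyl sulfur.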